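The compounds below may be only part of what the source reports. "The series", "measured", "known", "first", "only" and "open" are said of these compounds alone.

Compound 3 `NC(=O)c1ccc(-c2cnc(C(=O)CCc3ccc(-c4ccccc4)cc3)o2)nc1` stands second highest of the three numbers in an assay for inhibition of Fatty-acid amide hydrolase 1 (Rattus norvegicus) (a higher number here means a weaker inhibitor, a lower number a stronger inhibitor), giving 1.3 nM; compound 2 `NC(=O)c1cccc(-c2cnc(C(=O)CCc3ccc(-c4ccccc4)cc3)o2)n1` gives 1.2 nM, within the scatter of compound 3, while compound 1 `CN(C)C(=O)c1cnc(C(=O)CCc2ccc(COc3ccccc3)cc2)o1` gives 6.7 nM, beyond it. Compound 4 `CN(C)C(=O)c1cnc(C(=O)CCc2ccc(-c3ccccc3)cc2)o1` differs from compound 3 in one place: dimethylcarbamoyl in place of 5-carbamoylpyridin-2-yl on an aromatic carbon. Among the measured compounds shown here, the only measured step, a 1.1-fold higher number from compound 2 to compound 3 (0.03 log units; within the scatter), exchanges one carbamoylpyridinyl for another and does not bear on this change. Compound 1 carries the dimethylcarbamoyl group but also differs from compound 3 in a second place, so its higher number is only a hint. Compound 4 is therefore expected to give a somewhat higher number, a 4.6-fold higher number from compound 3 to compound 4 (0.66 log units; beyond the scatter), estimated at 6 nM with a range from 2 nM to 20 nM.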

Compound 4, inhibition constant: 3 nM
Compound 4: middle estimate off by 2.0-fold (0.30 log units), on the high side; the range from low to high includes it.
By their numbers in this assay, from the lowest: compounds 2 and 3 (each within the scatter of the next); then compound 4; then compound 1.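

In this assay, at the ring carbon next to the ring oxygen, dimethylcarbamoyl stays close to the two carbamoylpyridinyl groups but does not match them, with a 2.3-fold higher number from compound 3 to compound 4 (0.36 log units; beyond the scatter) and a 2.5-fold higher number from compound 2 to compound 4 (0.40 log units; beyond the scatter). With dimethylcarbamoyl held fixed, phenyl in place of phenoxymethyl gives a 2.2-fold lower number from compound 1 to compound 4 (0.35 log units; beyond the scatter), so that exchange alone moves the number modestly. No measurement at hand explains either shift. The compounds shown do not separate the contribution of the pyridine ring from that of the amide hydrogens. As far as these compounds go, how a carboxylic acid or a methyl ester would stand at this position also remains open.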